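The source may hold more compounds than are shown below. What is called first, only, known or untested is meant among the compounds shown, and "the series" means these compounds.

Measured in a functional assay on A549 cells (Homo sapiens) for antiproliferative activity, read by CCK-8 assay, with a stated time of 72 h; a lower number here means a stronger inhibitor, a higher number a weaker inhibitor:

compound 1 `COc1ccc(C(=O)Nc2cccc(-c3oc4cc(-c5ccc(F)cc5)ccc4c(=O)c3O)c2)cc1` gives 8700 nM
compound 2 `O=C(Nc1cccc(-c2oc3cc(-c4ccc(F)cc4)ccc3c(=O)c2O)c1)c1ccc(F)cc1F` gives 20500 nM
compound 3 `COc1cccc(C(=O)Nc2cccc(-c3oc4cc(-c5ccc(F)cc5)ccc4c(=O)c3O)c2)c1` gives 10800 nM

Compound 3 gives the middle of the three numbers. Its nearest neighbour is compound 1, and the step of a 1.2-fold higher number from compound 1 to compound 3 (0.09 log units; within the scatter) is within the scatter; its furthest is compound 2, and the step of a 1.9-fold lower number from compound 2 to compound 3 (0.28 log units; within the scatter) is also within the scatter. Within the data shown here, the only step beyond the scatter in this assay is a 2.4-fold higher number from compound 1 to compound 2 (0.37 log units; beyond the scatter), which is modest.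

Compound 4 `CCc1ccc(C(=O)Nc2cccc(-c3oc4cc(-c5ccc(F)cc5)ccc4c(=O)c3O)c2)cc1` differs from compound 3 by 4-ethylphenyl in place of 3-methoxyphenyl on a carbonyl carbon. Among the measured compounds shown here, no measured step replaces a methoxyphenyl with an alkyl-bearing phenyl at this carbonyl carbon, so the bearing of the three steps is indirect. Moving the methoxy group from one ring position to another, as in a 1.2-fold higher number from compound 1 to compound 3 (0.09 log units; within the scatter), left the number within the scatter, and exchanging it for two fluorines, as in a 2.4-fold higher number from compound 1 to compound 2 (0.37 log units; beyond the scatter), moved it only modestly. The whole series spans little more than the scatter itself.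

The expected step of a 1.0-fold higher number from compound 3 to compound 4 (0.01 log units; within the scatter) is therefore none beyond the scatter, or a modest weakening at most, in line with the other aryl replacements. Compound 4 is estimated at 11000 nM in this assay, with a range from 5000 nM to 25000 nM.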

Compound 4, half-maximal inhibitory concentration: 18500 nM
Compound 4: middle estimate off by 1.7-fold (0.23 log units), on the low side; the measured number falls inside the stated range.
By their numbers in this assay, from the lowest: compounds 1, 3, 4 and 2 (each within the scatter of the next, the first and the last beyond it).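

In this assay, among these compounds, the step of a 2.1-fold higher number from compound 1 to compound 4 (0.33 log units; beyond the scatter) is the first direct exchange of methoxy for an alkyl group on this aromatic carbon, and it is modest but beyond the scatter, so 4-ethylphenyl and 4-methoxyphenyl can be told apart on this carbonyl carbon. The other two steps (a 1.7-fold higher number from compound 3 to compound 4 (0.23 log units; within the scatter)) and (a 1.1-fold lower number from compound 2 to compound 4 (0.04 log units; within the scatter)) stay within the scatter, so 4-ethylphenyl cannot be told apart from 3-methoxyphenyl or 2,4-difluorophenyl; among the four compounds, only compound 1 stands apart from compound 2 and compound 4, while compound 3 lies within the scatter of all three. Nothing on hand offers an explanation for the difference between ethyl and methoxy at this position.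

The aryl groups shown carry only methoxy, fluoro or ethyl substituents, so it stays open whether an amine, a carboxylic acid or a longer chain such as butyl on this ring would produce more than a modest step. Also open, from the compounds shown here alone, is whether 3-ethylphenyl would fall within the scatter of 4-ethylphenyl, as 3-methoxyphenyl does of 4-methoxyphenyl.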